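A few compounds are considered here, and "the series" means these few. Any claim that something is new, unique, unknown or untested is made for them only; others in the source may bear on it.

Working notes on the series in an ADME assay on MT4 cells (Homo sapiens) for cytotoxicity, read by MTT assay, with a stated time of 4 days; a higher number here means that more compound is tolerated, a lower number that less compound is tolerated.

Compound 1 `CN(C)c1nc(Cc2c(F)cccc2F)cc(=O)[nH]1` is the smallest member of the set. In this assay compound 1 gives a value of > 94000 nM, which is a limit of the assay rather than a number. Compound 2 `CCN(C)c1nc(Cc2c(F)cccc2F)cc(=O)[nH]1` differs from compound 1 by methyl in place of hydrogen on a saturated chain carbon bound to a nitrogen on an aromatic ring. In this assay compound 2 gives > 89000 nM, again a limit and not a number. Accordingly the step that the two limits leave unreadable from compound 1 to compound 2 cannot be read; the two limits the limit of > 94000 nM in this assay, at which 1 of the 3 values shown sits, and the limit of > 89000 nM in this assay, at which 1 of the 3 values shown sits, are all that is known of it. Compound 3 `CCN(C)c1nc(Cc2c(F)cccc2F)c(C)c(=O)[nH]1` carries a methyl in place of hydrogen on an aromatic carbon relative to compound 2. In this assay compound 3 gives > 85000 nM, once more a limit of the assay. The step that the two limits leave unreadable from compound 2 to compound 3 is therefore equally unreadable, resting only on the limit of > 89000 nM in this assay, at which 1 of the 3 values shown sits, and (the limit of > 85000 nM in this assay, at which 1 of the 3 values shown sits). How the core of compound 3 differs from the core of compound 1 is not broken down here.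

Compound 4 `Cc1c(Cc2c(F)cccc2F)nc(N(C)C(C)C)[nH]c1=O` is not yet measured. It differs from compound 3 by methyl in place of hydrogen on a saturated chain carbon bound to a nitrogen on an aromatic ring and a saturated chain carbon. This is the same kind of change as that from compound 1 to compound 2, but the place is not identical: in compound 4 the saturated chain carbon is bound to a nitrogen on an aromatic ring and a saturated chain carbon, whereas in compound 2 it is bound to a nitrogen on an aromatic ring only. Since compound 1, compound 2 and compound 3 all sit at limits, the earlier step gives no readable size to lean on. The step of a number no higher from compound 3 to compound 4 (the limit leaves the size open) is expected to stay within the scatter, because compound 3 already sits at the limit of > 85000 nM in this assay, at which 1 of the 3 values shown sits, and no member of the set has shown measurable cytotoxicity. Compound 4 is expected to give about 85000 nM in this assay, most likely reported again only as a limit, with a plausible range of 40000 nM to 160000 nM.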

Compound 4, half-maximal cytotoxic concentration: 79000 nM
The estimate for compound 4 lay 1.1-fold (0.03 log units) above the measured number, and the stated range covers the measured number.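

In this assay, the change from ethyl to isopropyl on the core of compound 3 gives an at least 1.0-fold lower number from compound 3 to compound 4 (0.03 log units; that floor lies within the scatter), so the only readable result of this change is a floor within the scatter, and no real difference can be claimed from it. Compound 3 stands only at a limit of the assay, which leaves the true size of the step open: the limit of > 85000 nM in this assay, at which 1 of the 4 values shown sits. The steps from compound 1 to compound 2 and from compound 2 to compound 3 cannot be read, so nothing shows whether the methyl-for-hydrogen change carries from one core to the other, and the place also differs, since in compound 4 the carbon is bound to a nitrogen on an aromatic ring and a saturated chain carbon.

As far as these compounds go, whether a longer chain, a cyclic amine or a carboxylic acid in that place would give a number well under these limits stays open. Compound 4 is the only compound shown with a number rather than a limit, so the set offers no comparison between two numbers.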